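A few compounds are considered here, and "the series" means these few. Any claim that something is new, unique, unknown or untested is made for them only; others in the source may bear on it.

Going by the values given here, compound 2 `CC(O)(C(=O)Nc1ccc(S(N)(=O)=O)cc1)C(F)(F)F` gives 12800 nM in an assay on a protein complex (Cavia porcellus) with sulfonylurea receptors; K-ATP channels (Homo sapiens) as the target (on this read-out lower numbers stand for stronger inhibition and higher numbers for weaker inhibition), the lower of the two numbers measured so far. Compound 1 `Cn1nnnc1-c1ccc(NC(=O)C(C)(O)C(F)(F)F)cc1` gives 30900 nM in this assay. Among the compounds with values here, the only measured step, a 2.4-fold lower number from compound 1 to compound 2 (0.38 log units; beyond the scatter), concerns an exchange on the same aromatic carbon of the shared core. Compound 3 `CC(O)(C(=O)Nc1ccc([C@H](O)c2ccccc2)cc1)C(F)(F)F` carries a different exchange at that carbon: hydroxy(phenyl)methyl in place of sulfamoyl on an aromatic carbon. Within the data shown here, no measured pair shows this particular exchange, so the step from compound 1 to compound 2 is the only guide, and that step was modest in size. A change of modest size is therefore expected for compound 3 as well, with no firm direction, and the estimated step is a 1.4-fold lower number from compound 2 to compound 3 (0.15 log units; within the scatter). In this assay compound 3 is expected to give about 9000 nM, with a plausible range from 2000 nM to 40000 nM.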

Compound 3, half-maximal inhibitory concentration: > 30000 nM
Compound 3: only a limit was reported (the forecaster's own chance of this, stated with the estimate: 10%); middle value at least 3.3-fold (0.52 log units) away from the limit.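

The earlier compounds shown here showed only that sulfamoyl gives a lower number than 1-methyl-1H-tetrazol-5-yl at this aromatic carbon. Putting the larger hydroxy(phenyl)methyl group there in place of sulfamoyl brings an at least 2.3-fold higher number from compound 2 to compound 3 (0.36 log units; beyond the scatter), so the number at this position can rise as well as fall, and the change means weaker inhibition. The reading for compound 3 is a limit: the limit of > 30000 nM in this assay, at which 1 of the 3 values shown sits. The step from compound 1 to compound 3 cannot be read, so those two groups cannot be ranked against each other.

The compounds shown do not separate the phenyl ring of hydroxy(phenyl)methyl from its hydroxy group, so it stays open which part goes with the higher number. From the compounds shown here alone, how an amine or a carboxylic acid would read at this aromatic carbon also stays open.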